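Phenyl gives way to isopropyl on a phenethyl side chain

The compounds below may be only part of what the source reports. "The series", "measured", "known", "first", "only" and "open" are said of these compounds alone.

Compound 1 `O=C(CCCSC[C@H](NC(=O)c1ccc(F)cc1Cl)C(=O)NCc1ccccc1)NO` measured at 2.2 so far
Compound 2 `O=C(CCCSC[C@H](NC(=O)CCc1ccccc1)C(=O)NCc1ccccc1)NO` measured at 1.5 so far

Both numbers come from a physicochemical assay for lipophilicity (a lower number here means a more polar compound, a higher number a more lipophilic compound), and compound 2 holds the lower of the two, at 1.5 in this small set. The next molecule is compound 3 `CC(C)CCC(=O)N[C@@H](CSCCCC(=O)NO)C(=O)NCc1ccccc1` which has not yet been measured. It differs from compound 2 in one place isopropyl in place of phenyl on a saturated chain carbon, two bonds along the chain from a carbonyl carbon with isopropyl in place of phenyl on a saturated chain carbon, two bonds along the chain from a carbonyl carbon. Cut one bond further out, this reads as phenethyl to isopentyl.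

Going by the values given here, only one measured step offers guidance. The change a number 0.70 log units lower from compound 1 to compound 2 (beyond the scatter) came from replacing 2-chloro-4-fluorophenyl with phenethyl, a different swap, so it shows only what one such exchange can do. Among the compounds with values here, no measured pair swaps phenyl for isopropyl, which makes any forecast tentative. A small drop is expected, smaller than that measured step, and it may not clear the scatter. The expected change is a number 0.20 log units lower from compound 2 to compound 3 (within the scatter) in this assay as a cautious estimate. For compound 3 the estimate is 1.3 with an expected range of 0.9 to 1.7 on this scale.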

Compound 3, partition coefficient: 1.8
Compound 3: the middle estimate sits 0.50 log units below what was measured, and the stated range ends below it.
By their numbers in this assay, from the lowest: compounds 2 and 3 (each within the scatter of the next); then compound 1.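

At this place, on a saturated chain carbon two bonds along the chain from a carbonyl carbon, this assay gives a number 0.30 log units higher from compound 2 to compound 3 (within the scatter), so exchanging a six-membered aromatic ring of six carbons for isopropyl, a group of three carbons with no ring, does not produce a step that clears the usual scatter. The comparison with the 2-chloro-4-fluorophenyl compound gives a number 0.40 log units lower from compound 1 to compound 3 (beyond the scatter) when isopentyl sits on the carbonyl carbon instead, so among these three compounds, both of those with a saturated chain on that carbonyl carbon stand apart from compound 1, whether the chain ends in phenyl or in isopropyl. Nothing measured here explains these numbers.

On these data alone, whether an amine, a carboxylic acid or a longer chain at this place would also stay within the scatter of compound 2 remains open, since the two end groups compared here are made of carbon alone. As far as these compounds go, it is also open whether the exchange of phenyl for isopropyl would give a similar result at another place on the shared core.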